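Replacing a ring amide with an open chain amide

The source may report more compounds than this note shows. Statements on the series, on what has been measured and on what is new or still open speak of the compounds shown alone.

Of the compounds shown here, three that share one core have been measured in a functional assay on L6 cells (Rattus norvegicus) for inhibition; on this read-out lower numbers stand for stronger inhibition and higher numbers for weaker inhibition. Compound 1 `CC(C)c1c(C(=O)N(C)Cc2ccccc2)nn(-c2ccc(F)cc2)c1CC[C@@H](O)C[C@@H](O)CC(=O)O` gives 2870 nM. Compound 2 `CC(C)c1c(C(=O)N2CCC[C@H](c3ccccc3)C2)nn(-c2ccc(F)cc2)c1CC[C@@H](O)C[C@@H](O)CC(=O)O` gives 310 nM, and the change a 9.3-fold lower number from compound 1 to compound 2 (0.97 log units; beyond the scatter). Compound 3 `CC(C)c1c(C(=O)N2CCC[C@H](c3ccccc3)C2)nn(-c2ccc(F)cc2)c1OC[C@@H](O)C[C@@H](O)CC(=O)O` gives 1110 nM; the change from compound 2 to compound 3 is a 3.6-fold higher number from compound 2 to compound 3 (0.55 log units; beyond the scatter). Among the three numbers compound 3 stands second highest, nearest to compound 1 and furthest from compound 2.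

Compound 4 `CC(C)c1c(C(=O)NCc2ccccc2Cl)nn(-c2ccc(F)cc2)c1OC[C@@H](O)C[C@@H](O)CC(=O)O` differs from compound 3 in one place: (2-chlorobenzyl)amino in place of 3-phenylpiperidin-1-yl on a carbonyl carbon. Among the measured compounds shown here, the only measured step that bears on this change is the one from compound 1 to compound 2, where a 3-phenylpiperidin-1-yl group replaced an open chain amine on the same carbonyl carbon and gave a 9.3-fold lower number from compound 1 to compound 2 (0.97 log units; beyond the scatter). For the measured compounds named here, the present change runs in the opposite sense, going back to an open chain amine, so the number is expected to rise by a 4.1-fold higher number from compound 3 to compound 4 (0.61 log units; beyond the scatter), though the chlorine-bearing benzyl group has no measured counterpart here. Compound 4 is therefore estimated at 4500 nM in this assay, within a range from 1300 nM to 16000 nM.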

Compound 4, half-maximal inhibitory concentration: 8450 nM
For compound 4 the middle estimate is 1.9-fold (0.27 log units) below the measured one; the range from low to high includes it.
By their numbers in this assay, from the lowest: compound 2; then compound 3; then compound 1; then compound 4.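

In this assay the swap on the carbonyl carbon gives a 7.6-fold higher number from compound 3 to compound 4 (0.88 log units; beyond the scatter), so the open chain amine again carries the higher number, this time with the (5-carboxy-2,4-dihydroxypentyl)oxy side chain rather than the 6-carboxy-3,5-dihydroxyhexyl chain of a 9.3-fold lower number from compound 1 to compound 2 (0.97 log units; beyond the scatter). The preference for 3-phenylpiperidin-1-yl over an open chain amine therefore holds in both pairs shown, even though the open chain groups differ and the one in compound 4 carries a chlorine and an amide hydrogen. Nothing at hand explains why the number rises with this change.

As far as these compounds go, compound 4 changes several features at once, so the share of each remains unknown. A plain benzylamino group, or an N-methyl-2-chlorobenzylamino group, on the same side chain would help separate the chlorine from the amide hydrogen.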